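Benzylamino for piperidinyl on the purine-type core of compound 1

This account rests on a few compounds, and the source may have more. Where it says the series, first, only, none or still open, it means among the compounds named here.

The two measured compounds, both read in a functional assay on A549 cells (Homo sapiens) for inhibition, read by MTT assay, with a stated time of 72 h; on this read-out lower numbers stand for stronger inhibition and higher numbers for weaker inhibition:
Compound 1 `CCCSc1nc(N2CCCCC2)c2nc(/C=C/C(=O)c3ccc(C)cc3)n(Cc3ccccc3)c2n1` gives > 32000 nM, which is a limit of the assay and not a number.
Compound 2 `CCCSc1nc(Cl)c2c(n1)N(Cc1ccccc1)C(C(=O)NCCCc1ccccc1)N2` gives 9430 nM.

Compound 1 stands at the limit, as described by the limit of > 32000 nM in this assay, at which 1 of the 2 values shown sits, so its inhibition is known only to be weaker than that value. Among the measured compounds shown here, compound 2 is the only compound with a number, and no step between it and compound 1 is described; the two values show only that compound 2 reached a measurable concentration where compound 1 did not.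

Compound 3 `CCCSc1nc(NCc2ccccc2)c2nc(/C=C/C(=O)c3ccc(C)cc3)n(Cc3ccccc3)c2n1` differs from compound 1 in one place: benzylamino in place of piperidin-1-yl on an aromatic carbon. For the measured compounds named here, no measured step covers this change, so the expectation rests on the standing of compound 1 alone, which is a limit. The step of an at least 1.6-fold lower number from compound 1 to compound 3 (0.20 log units; that floor lies within the scatter) is expected to be modest, perhaps a gain beyond the scatter but not a large one. Compound 3 is therefore estimated at 20000 nM in this assay, with a range from 6000 nM to 70000 nM, and a fair chance that only a limit is reported again.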

Compound 3, half-maximal inhibitory concentration: 30100 nM
The estimate for compound 3 lay 1.5-fold (0.18 log units) below the measured number, within the range that was stated.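

In this assay, the exchange of piperidin-1-yl for benzylamino at this position can be read only as an at least 1.0-fold lower number from compound 1 to compound 3 (0.02 log units; that floor lies within the scatter), so no gain beyond the scatter can be claimed for it. Among the compounds shown here, what the change adds is a first number on this core, since compound 3, which carries a hydrogen-bond donor and a carbon-only aromatic ring in this place, gives 30100 nM where the piperidin-1-yl compound gave no number. Going by these compounds, the other side of the step remains a limit and not a number, so the true size of the step stays unknown, and compound 1 is described only by it: the limit of > 32000 nM in this assay, at which 1 of the 3 values shown sits.

On these data alone, it remains open whether another substituent on this aromatic carbon, such as a morpholin-4-yl group, a plain primary amine or a phenethylamino group with its longer chain, would bring the value clearly beyond the scatter from that of compound 3. Compound 2 differs from compound 3 in more than one place, so the compounds shown also do not tell which part of the structure sets the level of inhibition on these cells.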